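This account rests on a few compounds, and the source may have more. Where it says the series, first, only, none or still open, it means among the compounds named here.

In an assay on isolated protein for binding affinity to adenosine receptor A1 (Bos taurus) (on this read-out lower numbers stand for stronger inhibition and higher numbers for weaker inhibition), three compounds sharing one core have been measured:

Compound 1 `CCCCNc1nc(-c2ccccc2)nc2c1nnn2Cc1ccccc1` gives 11000000 nM.
Compound 2 `c1ccc(Cn2nnc3c(NC4CCCC4)nc(-c4ccccc4)nc32)cc1` gives 11000000 nM.
Compound 3 `CCNc1nc(-c2ccccc2)nc2c1nnn2Cc1ccccc1` gives 91000000 nM.

Compound 3 stands at the highest number of the three, that is, it is the weakest binder here: an 8.3-fold higher number from compound 1 to compound 3 (0.92 log units; beyond the scatter) and an 8.3-fold higher number from compound 2 to compound 3 (0.92 log units; beyond the scatter) both lie beyond the scatter, while compound 1 and compound 2 show no change at the digits printed from compound 1 to compound 2 (within the scatter).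

Compound 4 `c1ccc(Cn2nnc3c(NC4CCC4)nc(-c4ccccc4)nc32)cc1` differs from compound 3 in one place: cyclobutyl in place of ethyl on a nitrogen on an aromatic ring. The measured step that bears most directly on this is an 8.3-fold higher number from compound 2 to compound 3 (0.92 log units; beyond the scatter), where swapping the ring for the small chain raised the number by a modest amount. The other step, no change at the digits printed from compound 1 to compound 2 (within the scatter), shows that a butyl chain and a cyclopentyl ring give the same number within the scatter. Among the compounds with values here, a cyclobutyl ring lies in size between ethyl and cyclopentyl, so the move from compound 3 to compound 4 is expected to bring a lower number, most likely a step close to reversing the one from compound 2 to compound 3, though possibly a little short of it.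

For compound 4 the expected result is 15000000 nM, with a range from 5000000 nM to 45000000 nM, which is meant to be a step of a 6.1-fold lower number from compound 3 to compound 4 (0.78 log units; beyond the scatter).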

Compound 4, inhibition constant: 5000000 nM
Compound 4: middle estimate off by 3.0-fold (0.48 log units), on the high side; measured number inside the range.
By their numbers in this assay, from the lowest: compound 4; then compounds 1 and 2 (each within the scatter of the next); then compound 3.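

In this assay, the change at this nitrogen produces a large step: cyclobutyl in place of ethyl gives an 18-fold lower number from compound 3 to compound 4 (1.26 log units; beyond the scatter) and so places compound 4 at the lowest number of the four. The earlier compounds shown here left open whether a group of this kind could do better than butyl and cyclopentyl, which gave the same printed number, and the answer here is yes, by a modest margin beyond the scatter, with a 2.2-fold lower number from compound 1 to compound 4 (0.34 log units; beyond the scatter) and a 2.2-fold lower number from compound 2 to compound 4 (0.34 log units; beyond the scatter). The number therefore does not simply fall as the group on this nitrogen grows, since the smaller cyclobutyl ring gives a lower number than the larger cyclopentyl ring, and no measurement shown here accounts for this order.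

On these data alone, whether a cyclopropyl or a cyclohexyl ring on this nitrogen would give a number lower than that of compound 4 remains open, so the four compounds do not show where the best ring size lies. Also open, as far as these compounds go, is how a branched chain such as isopropyl, or a cyclobutyl ring carrying a hydroxyl group, would compare in this position.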